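The compounds below may be only part of what the source reports. "The series", "measured", "known", "first", "only" and "open" are said of these compounds alone.

In a functional assay on PC-3 cells (Homo sapiens) for inhibition, read by MTT assay, with stated times of 18 h and 4 h (a lower number here means a stronger inhibitor, a higher number a weaker inhibitor), compound 1 `CCCCCCCCCCCCCCCCOP(=O)(O)OCCSC(=S)N1CCCCCC1` gives 32100 nM as its value, compound 2 `CCCCCCCCCCOP(=O)(O)OCCSC(=S)N1CCCCCC1` gives 32900 nM and compound 3 `CCCCCCCCOP(=O)(O)OCCSC(=S)N1CCCCCC1` gives 56800 nM on the same read-out. Compound 3 therefore stands within the scatter of both others: a 1.7-fold higher number from compound 2 to compound 3 (0.24 log units; within the scatter) and a 1.8-fold higher number from compound 1 to compound 3 (0.25 log units; within the scatter) are the two steps that reach it, and a 1.0-fold higher number from compound 1 to compound 2 (0.01 log units; within the scatter) is equally small.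

Compound 4 `CCCCCCOP(=O)(O)OCCSC(=S)N1CCCCCC1` remains unmeasured. Its difference from compound 3 is hydrogen in place of ethyl on a saturated chain carbon, six bonds along the chain from an oxygen on an unsaturated carbon in the counted form, that is, hydrogen in place of ethyl on a saturated chain carbon, six bonds along the chain from an oxygen on an unsaturated carbon. Among the measured compounds shown here, the closest precedent is a 1.7-fold higher number from compound 2 to compound 3 (0.24 log units; within the scatter) for the same replacement, eight bonds along the chain. With three compounds, all within the scatter, no trend can be claimed, and nothing shows how the series behaves at six bonds.

The expected change is a 1.3-fold higher number from compound 3 to compound 4 (0.12 log units; within the scatter) as an estimate, which stays within the scatter. The estimate for compound 4 is 75000 nM in this assay with an expected range from 40000 nM to 160000 nM on repeat measurement.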

Compound 4, half-maximal inhibitory concentration: > 100000 nM
Compound 4 ended at the assay's limit; the forecaster's own chance of this, stated with the estimate: 20%; middle value at least 1.3-fold (0.12 log units) from the limit.
By their numbers in this assay, from the lowest: compounds 1, 2 and 3 (each within the scatter of the next). At a limit, above all of these: compound 4.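

In this assay, compound 4 reads > 100000 nM, which is a limit of the assay and not a number. Among the compounds shown here, with hydrogen in place of ethyl, six bonds along the chain from an oxygen on an unsaturated carbon, the series shows an at least 1.7-fold higher number from compound 3 to compound 4 (0.24 log units; that floor lies within the scatter), a floor that does not separate that pair, while an at least 3.0-fold higher number from compound 2 to compound 4 (0.48 log units; beyond the scatter) and an at least 3.1-fold higher number from compound 1 to compound 4 (0.49 log units; beyond the scatter) are the first steps to pass beyond the scatter. The true size of all three steps cannot be read because compound 4 stands at a limit: the limit of > 100000 nM in this assay, at which 1 of the 4 values shown sits.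

Still open, going by these compounds, is whether the chain of compound 4 marks a sharp cut-off or part of a gradual fall. Also open, on these data alone, is whether a butyl chain, or an amine or carboxylic acid carried on the chain, would give a measurable number.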